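The source may report more compounds than this note shows. Statements on the series, on what has been measured and on what is new or still open speak of the compounds shown alone.

Compound 1 `CSc1nc(Cl)c(C(=O)c2ccccc2)s1`: > 100000 nM (a limit)
Compound 2 `CSc1nc(Br)c(C(=O)c2ccccc2)s1`: 97000 nM
Compound 3 `N#Cc1sc(N2CCCC2)nc1Cl`: > 100000 nM (a limit)

These three compounds were tested in a functional assay on A549 cells (Homo sapiens) for cytotoxicity, read by MTT assay, with a stated time of 72 h; a higher number here means a weaker inhibitor, a lower number a stronger inhibitor. Compound 1 stands at the limit of > 100000 nM in this assay, at which 2 of the 3 values shown sit, so it offers a limit and not a number. Compound 4 `O=C(c1ccccc1)c1sc(N2CCCCC2)nc1Cl` is reached from it by one change, (piperidin-1-yl in place of methylsulfanyl on an aromatic carbon), which puts piperidin-1-yl in place of methylsulfanyl on an aromatic carbon.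

Within the data shown here, no measured step covers this change. The only one, an at least 1.0-fold lower number from compound 1 to compound 2 (0.01 log units; that floor lies within the scatter), is bromo in place of chloro on an aromatic carbon, so it concerns another group and says little here. Compound 3 also carries a non-aromatic ring with a nitrogen, and its result in this assay is likewise a limit, > 100000 nM.

Nothing measured therefore points to a large step, and at most a modest move to a lower number is expected. The expected step is an at least 1.4-fold lower number from compound 1 to compound 4 (0.15 log units; that floor lies within the scatter). Compound 4 is estimated at 70000 nM, with an expected range from 20000 nM to 150000 nM.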

Compound 4, half-maximal inhibitory concentration: 41000 nM
Estimate against measurement, compound 4: 1.7-fold (0.23 log units) above; low and high end bracket the measured number.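

In this assay, the aromatic carbon next to the ring nitrogen and next to the ring sulfur proves responsive to the group it carries: piperidin-1-yl in place of methylsulfanyl gives an at least 2.4-fold lower number from compound 1 to compound 4 (0.38 log units; beyond the scatter). Among these compounds, this is the first step that lies beyond the scatter, whereas bromo in place of chloro gave only an at least 1.0-fold lower number from compound 1 to compound 2 (0.01 log units; that floor lies within the scatter). The true size of the new step remains unknown, as the value of compound 1 is a limit and the step only a floor: the limit of > 100000 nM in this assay, at which 2 of the 4 values shown sit.

The compounds shown leave open whether the ring of piperidin-1-yl or its nitrogen matters more, a question that morpholine or an open-chain dimethylamino group at this carbon could address. Also open, from the compounds shown here alone, is whether bromo in place of chloro would change the number for compound 4.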